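Compound 3 and a benzofuran swap

The source may hold more compounds than are shown below. What is called first, only, known or untested is meant among the compounds shown, and "the series" means these compounds.

Measured in a functional assay on A549 cells (Homo sapiens), read by MTT assay, with a stated time of 72 h; on this read-out higher numbers stand for weaker inhibition and lower numbers for stronger inhibition:
- Compound 1 `COc1ncnc2c1c(-c1cc3ccccc3o1)cn2[C@@H]1O[C@H](CO)[C@@H](O)[C@H]1O`: 17700 nM
- Compound 2 `COc1nc(N)nc2c1c(-c1cccs1)cn2[C@@H]1O[C@H](CO)[C@@H](O)[C@H]1O`: > 20000 nM (a limit)
- Compound 3 `COc1nc(N)nc2c1c(-c1ccsc1)cn2[C@@H]1O[C@H](CO)[C@@H](O)[C@H]1O`: > 100000 nM (a limit)

Compound 3 stands at > 100000 nM, which is a limit and not a number. Compound 2 also gives only a limit, > 20000 nM. Only compound 1 has a true number.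

The next compound, compound 4 `COc1nc(N)nc2c1c(-c1cc3ccccc3o1)cn2[C@@H]1O[C@H](CO)[C@@H](O)[C@H]1O`, puts 1-benzofuran-2-yl in place of thiophen-3-yl on an aromatic carbon.

Within the data shown here, the one measured step, a step that the two limits leave unreadable from compound 2 to compound 3, has no readable size and offers little guidance. The better clue is compound 1, which carries the same 1-benzofuran-2-yl group on a different core and gives 17700 nM. A move towards lower numbers in this assay is therefore expected, although its size is uncertain and a limit could appear again.

The estimated step is an at least 5.0-fold lower number from compound 3 to compound 4 (0.69 log units; beyond the scatter). For compound 4 the expected value is 20000 nM, with an estimated range from 6000 nM to 70000 nM.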

Compound 4, half-maximal inhibitory concentration: > 20000 nM
Compound 4: no number, only a limit (the forecaster's own chance of this, stated with the estimate: 40%); the middle value sits exactly at the limit.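

In this assay, compound 4 gives a limit and not a number, so 1-benzofuran-2-yl at this position, like thiophen-2-yl and thiophen-3-yl, leaves the compounds with the amino group without a true value: the limit of > 20000 nM in this assay, at which 2 of the 4 values shown sit. The steps to compound 4 from compound 2 and from compound 3 cannot be read, as each joins two limits. Among these compounds, the one readable step is an at least 1.1-fold higher number from compound 1 to compound 4 (0.05 log units; that floor lies within the scatter) and comes with amino in place of hydrogen on an aromatic carbon, and its true size could be small or large.

As far as these compounds go, how far the true value of compound 4 lies past its limit remains open. Also open, from the compounds shown here alone, is whether a carboxylic acid or an aminomethyl group in place of 1-benzofuran-2-yl at this position would give a true number on the shared core.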